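A few compounds are considered here, and "the series" means these few. Any claim that something is new, unique, unknown or untested is made for them only; others in the source may bear on it.

Measured in a functional assay on PC-3 cells (Homo sapiens) for cytotoxicity, read by MTT assay, with a stated time of 48 h; on this read-out lower numbers stand for stronger inhibition and higher numbers for weaker inhibition:
- compound 1 `COc1ccc(-c2c[nH]c(=O)n2-c2cc(OC)c(OC)c(OC)c2)cc1[N+](=O)[O-]`: > 50000 nM (a limit)
- compound 2 `COc1ccc(-c2cn(C(C)=O)c(=O)n2-c2cc(OC)c(OC)c(OC)c2)cc1`: 19700 nM
- compound 3 `COc1ccc(-c2cn(C(C)=O)c(=O)n2-c2cc(OC)c(OC)c(OC)c2)cc1OC`: > 50000 nM (a limit)

Compound 3 gives no number, only a limit. It stands at the limit of > 50000 nM in this assay, at which 2 of the 3 values shown sit. Compound 4 `COc1ccc(-c2cn(C(C)=O)c(=O)n2-c2cc(OC)c(OC)c(OC)c2)cc1[N+](=O)[O-]` has nitro in place of methoxy on an aromatic carbon, ortho to a methoxy group (nitro in place of methoxy on an aromatic carbon).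

For the measured compounds named here, only one measured step bears on this place: methoxy in place of hydrogen gave an at least 2.5-fold higher number from compound 2 to compound 3 (0.40 log units; beyond the scatter). That step shows that the ring position is sensitive in this assay, but it says nothing directly about nitro. Compound 1 also carries nitro, and its result is again the limit of > 50000 nM. With that evidence, no clear gain is expected, and compound 4 should remain weak, possibly at the limit. A small move to a lower number remains possible, but it is not firmly expected. The estimate amounts to an at least 1.4-fold lower number from compound 3 to compound 4 (0.15 log units; that floor lies within the scatter). Compound 4 is expected at 35000 nM, with an estimated range from 12000 nM to 50000 nM.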

Compound 4, half-maximal inhibitory concentration: 30300 nM
Beside the measured number, compound 4's estimate is 1.2-fold (0.06 log units) above it; the measured number falls inside the stated range.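

In this assay, nitro on this aromatic carbon gives an at least 1.6-fold lower number from compound 3 to compound 4 (0.21 log units; that floor lies within the scatter), so the step from methoxy yields a measured number but only a floor that does not separate the two groups. Set against hydrogen at the same place, nitro gives a 1.5-fold higher number from compound 2 to compound 4 (0.19 log units; within the scatter), which shows that this change, unlike the methoxy step, does not clearly shift the read-out. With nitro held in place, acetyl on the aromatic nitrogen gives an at least 1.6-fold lower number from compound 1 to compound 4 (0.21 log units; that floor lies within the scatter), and this too is only a floor, as one end of the step is a limit: the limit of > 50000 nM in this assay, at which 2 of the 4 values shown sit.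

On these data alone, whether an amine or a fluorine on this carbon would move the number beyond the scatter stays open. How far the acetyl group itself matters also remains unresolved.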